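From Compound 3 to Compound 4: an Estimate

This account rests on a few compounds, and the source may have more. Where it says the series, first, only, none or still open, it means among the compounds named here.

Compound 1, `COC(=[Se])Nc1ccc2c(C)cc(=O)oc2c1` — in a functional assay on HBL-100 cells (Homo sapiens) for inhibition, read by sulforhodamine B assay, with a stated time of 48 h (a higher number here means a weaker inhibitor of growth, a lower number a stronger inhibitor of growth), compound 1 gives > 100000 nM
Compound 2, `CCOC(=[Se])Nc1ccc2c(C)cc(=O)oc2c1` — compound 2 gives > 100000 nM
Compound 3, `CCCCOC(=[Se])Nc1ccc2c(C)cc(=O)oc2c1` — compound 3 gives "nd(insoluble)" (no result reported)

The value of compound 1 is a limit of the assay, not a number. The value of compound 2 is likewise a limit. The step that the two limits leave unreadable from compound 1 to compound 2 therefore cannot be read, since both of its ends sit at the limit of > 100000 nM in this assay, at which 2 of the 3 values shown sit. Compound 3 has no result at all in this assay; it is reported as insoluble, so no number places it among the others, and the two further values that exist in the series are limits.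

Compound 4, `CCCCNC(=[Se])Nc1ccc2c(C)cc(=O)oc2c1`, differs from compound 3 by butylamino in place of butoxy on a saturated chain carbon bound to a nitrogen on an aromatic ring. Among the compounds with values here, no measured step bears on this change. Within the data shown here, the only step, the one that cannot be read, concerns a different position and a different kind of exchange, and the starting compound 3 itself carries no number. The expectation for compound 4 can rest only on the fact that every reported value in the series is a limit.

Compound 4 is therefore expected to give about 150000 nM in this assay. For compound 4 the expected range is estimated to run from 40000 nM to 600000 nM, with a limit rather than a number the most likely outcome.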

Compound 4, concentration for 50% growth inhibition: 2300 nM
Beside the measured number, compound 4's estimate is 65-fold (1.81 log units) above it, and the stated range ends above it.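

In this assay, butylamino gives the series its first number rather than a limit, showing that this position can carry a measurable inhibitor of growth. Replacing the oxygen-linked chain with butylamino brings an at least 43-fold lower number from compound 2 to compound 4 (1.63 log units; beyond the scatter), and it also brings an at least 43-fold lower number from compound 1 to compound 4 (1.63 log units; beyond the scatter), although each of these exchanges alters the chain length as well as the linking atom. Both steps start from a limit and not from a number, and the one step among the earlier compounds cannot be read: the limit of > 100000 nM in this assay, at which 2 of the 4 values shown sit.

The only exchange that keeps the butyl chain and changes just the linking atom starts from compound 3, which has no result, so the compounds shown do not separate the part played by the nitrogen from that of the butyl chain. As far as these compounds go, how methylamino, ethylamino or a longer chain on the nitrogen such as hexylamino would read on the shared core remains open, as does the reading of a ring amine such as piperidine at this place.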